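The compounds below may be only part of what the source reports. "The series", "measured", "known", "first", "only" and "open" are said of these compounds alone.

Measured in a functional assay on PC-12 cells (Rattus norvegicus) for cytotoxicity, read by MTT assay, with stated times of 3 h and 2 h, tested at 5 uM; on this read-out higher numbers stand for a stronger effect at the one concentration tested and lower numbers for a weaker effect:
Compound 2, `O=C(CCCCC1CCSS1)NCc1cn(CCCCCOc2ccc3ccc(=O)oc3c2)nn1`, gives 64.5%.
Compound 1, `O=C(CCCCC1CCSS1)NCc1cn(CCCCOc2ccc3cc(-c4ccc(Br)cc4)c(=O)oc3c2)nn1`, gives 40.5%.

In this assay compound 2 holds the higher of the two numbers, and compound 1 stands lower by a gap that lies beyond the scatter. Compound 3, `Cc1cc(=O)oc2cc(OCCCCCn3cc(CNC(=O)CCCCC4CCSS4)nn3)ccc12`, differs from compound 2 in one place: methyl in place of hydrogen on an aromatic carbon. Within the data shown here, no pair of measured compounds shows what such a change does here, so the direction is uncertain. The step of a number 4.5 percentage points lower from compound 2 to compound 3 (within the scatter) is expected to be small, with no set direction, and probably within the scatter. Compound 3 is therefore estimated at 60%, in a range from 42% to 78%.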

Compound 3, a percentage reported as activity, at one concentration (the size of the read-out at that concentration, not a potency): 61%
The estimate for compound 3 lay 1 percentage points below the measured number, within the range that was stated.
By their numbers in this assay, from the lowest: compound 1; then compounds 3 and 2 (each within the scatter of the next).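

In this assay, methyl in place of hydrogen on an aromatic carbon, opposite the ring oxygen, gives a number 3.5 percentage points lower from compound 2 to compound 3 (within the scatter). Among these compounds, this is the first reading of this change at this position, and it shows that the position takes the methyl with no step beyond the scatter. Nothing available here offers an explanation for this result. The compounds shown leave open what an ethyl group, a methoxy group or an amine would do at the same carbon. They also leave open whether the methyl step would stay as small on a different linker chain.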